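A few compounds are considered here, and "the series" means these few. Any claim that something is new, unique, unknown or untested is made for them only; others in the source may bear on it.

Measured compounds:
Compound 1 `COC(=O)C(=O)CNC1=CS(=O)(=O)O[C@@]12[C@@H](CO[Si](C)(C)C(C)(C)C)O[C@@H](n1cc(C)c(=O)n(C)c1=O)[C@@H]2O[Si](C)(C)C(C)(C)C`
Compound 2 `Cc1cn([C@@H]2O[C@H](CO[Si](C)(C)C(C)(C)C)[C@@]3(OS(=O)(=O)C=C3NC(N)=O)[C@H]2O[Si](C)(C)C(C)(C)C)c(=O)n(C)c1=O`: 16000 nM
Compound 3 `Cc1cn([C@@H]2O[C@H](CO[Si](C)(C)C(C)(C)C)[C@@]3(OS(=O)(=O)C=C3NCCC(=O)O)[C@H]2O[Si](C)(C)C(C)(C)C)c(=O)n(C)c1=O`: 80000 nM

In a functional assay on HEL cells (Homo sapiens) for cytotoxicity, read by microscopy (on this read-out higher numbers stand for lower toxicity in this test and lower numbers for higher toxicity in this test), compound 1 gives only a limit, > 400000 nM (the limit of > 400000 nM in this assay, at which 1 of the 3 values shown sits). Compound 3 therefore stands with the highest of the two numbers shown, and its nearest neighbour is compound 2, with a 5.0-fold higher number from compound 2 to compound 3 (0.70 log units; beyond the scatter).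

Compound 4 `COC(=O)CNC1=CS(=O)(=O)O[C@@]12[C@@H](CO[Si](C)(C)C(C)(C)C)O[C@@H](n1cc(C)c(=O)n(C)c1=O)[C@@H]2O[Si](C)(C)C(C)(C)C` is the next compound and has not yet been measured. It differs from compound 3 in one place: methoxycarbonyl in place of carboxymethyl on a saturated chain carbon bound to an amine nitrogen. For the measured compounds named here, the measured step that bears on this change is the one from compound 1 to compound 3, an at least 5.0-fold lower number from compound 1 to compound 3 (0.69 log units; beyond the scatter), which moved in the opposite direction, from an ester-bearing chain to a free acid, and lowered the number. Returning to an ester-bearing chain is thus expected to raise the number in this assay by a modest amount, with a real chance that only a limit is reported again.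

Compound 4 is expected to give about 200000 nM, between 60000 nM and 400000 nM. The step expected from compound 3 to compound 4 is a 2.5-fold higher number from compound 3 to compound 4 (0.40 log units; beyond the scatter).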

Compound 4, minimum cytotoxic concentration: >= 400000 nM
Compound 4: no number, only a limit (the forecaster's own chance of this, stated with the estimate: 35%); middle value at least 2.0-fold (0.30 log units) from the limit.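

In this assay compound 4 joins compound 1 at a limit rather than a number: the limit of >= 400000 nM in this assay, at which 1 of the 4 values shown sits. With methoxycarbonyl in place of carboxymethyl on a saturated chain carbon bound to an amine nitrogen, the result is an at least 5.0-fold higher number from compound 3 to compound 4 (0.69 log units; beyond the scatter), so the gap seen earlier between an ester-bearing chain and the free acid also appears with this shorter ester chain. Against the carbamoyl group, (methoxycarbonyl)methyl on the amine nitrogen gives an at least 25-fold higher number from compound 2 to compound 4 (1.39 log units; beyond the scatter), and among the four compounds only the two ester-bearing chains end in limits, while carbamoyl and 2-carboxyethyl give numbers.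

On these data alone, no step can be read between the two limits of compound 1 and compound 4, so their order stays unknown. Where a primary amine or a hydroxyl group on this chain would fall in this assay also stays open.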